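Replacing the Hydroxyethyl Side Chain with a Benzyl Ester

The source may report more compounds than this note shows. Statements on the series, on what has been measured and on what is new or still open speak of the compounds shown alone.

Compound 3 `C[C@@H](O)[C@H](NC(=O)CN(c1nc(Cl)nc2[nH]cnc12)C1CC1)C(=O)OCc1ccccc1` gives 21.9% in a functional assay on the whole organism (Tail, strain ICR) with Mus musculus as the target, in the tail flick test, with a stated time of 30 min, at a dose of 25 umol/kg by the oral route (a lower number here means a weaker effect, a higher number a stronger effect of the compound at the dose given), the second highest of three numbers; compound 2 `O=C(CN(c1nc(Cl)nc2[nH]cnc12)C1CC1)NCC(=O)OCc1ccccc1` gives 18.7% and compound 1 `O=C(CN(c1nc(Cl)nc2[nH]cnc12)C1CC1)N[C@@H](CO)C(=O)OCc1ccccc1` gives 31.9%, both within the scatter of compound 3. Compound 4 `O=C(CN(c1nc(Cl)nc2[nH]cnc12)C1CC1)N[C@@H](CC(=O)OCc1ccccc1)C(=O)OCc1ccccc1` differs from compound 3 by (benzyloxycarbonyl)methyl in place of 1-hydroxyethyl on a saturated chain carbon bound to an amide-type nitrogen and a carbonyl carbon. Within the data shown here, two measured steps touch this carbon: a number 13.2 percentage points lower from compound 1 to compound 2 (beyond the scatter) lay beyond the scatter, whereas a number 3.2 percentage points higher from compound 2 to compound 3 (within the scatter) stayed within it. Since compound 4 also lacks a hydroxyl-bearing group at this carbon, as does compound 2 with 18.7%, the step of a number 4.9 percentage points lower from compound 3 to compound 4 (within the scatter) is expected to be a modest fall, close to the scatter. Compound 4 is therefore estimated to give 17%, with a range from 5% to 33%.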

Compound 4, a percentage reported as activity, at one dose (the size of the read-out at that dose, not a potency): 34.7%
Compound 4: middle estimate off by 17.7 percentage points, on the low side; the whole stated range lies below it.
By their numbers in this assay, from the lowest: compounds 2, 3, 1 and 4 (each within the scatter of the next, the first and the last beyond it).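

At the saturated chain carbon bound to an amide-type nitrogen and a carbonyl carbon, a hydroxy group proves unnecessary for the effect in this assay: (benzyloxycarbonyl)methyl gives a number 12.8 percentage points higher from compound 3 to compound 4 (beyond the scatter) and a number 16 percentage points higher from compound 2 to compound 4 (beyond the scatter). Benzyloxycarbonyl in place of hydroxy on the chain gives a number 2.8 percentage points higher from compound 1 to compound 4 (within the scatter), so the two groups cannot be told apart here. Nothing measured accounts for these steps. The compounds shown leave open whether a carboxylic acid in place of the benzyl ester on this side chain, or a longer chain carrying the same ester, would hold this level of effect.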